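This account rests on a few compounds, and the source may have more. Where it says the series, first, only, none or still open, it means among the compounds named here.

Two compounds of the series have numbers in a functional assay on PANC-1 cells (Homo sapiens) for inhibition, read by MTT assay, with a stated time of 24 h, tested at 10 uM (a lower number here means less inhibition, a higher number more inhibition at the concentration tested (going by the name of the read-out)), so far. Compound 1 `CC(C)=CCC/C(C)=C/CC1Cc2c(OCCCNC(=O)c3cccs3)cc(=O)n(CCCO)c2CC1(C)C` gives 11.5% in this assay, the higher of the two numbers; compound 2 `CC(C)=CCC/C(C)=C/CC1Cc2c(OCCCOc3ccc([N+](=O)[O-])cc3)cc(=O)n(CCCO)c2CC1(C)C` gives 9.8%. The one measured step, a number 1.7 percentage points lower from compound 1 to compound 2 (within the scatter), is within the scatter, so on the numbers shown the two compounds are not distinguishable.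

Compound 3 `CC(C)=CCC/C(C)=C/CC1Cc2c(OC(=O)Nc3ccc(F)cc3)cc(=O)n(CCCO)c2CC1(C)C` is not yet measured. It differs from compound 1 in one place: (4-fluorophenyl)carbamoyl in place of 3-(((thiophen-2-yl)carbonyl)amino)propyl on an oxygen on an aromatic ring. Within the data shown here, the measured step exchanges only the terminus of the three-carbon chain; no measured step removes the chain itself or installs a carbamoyl on the aromatic oxygen, so nothing here bears directly on this change. With both measured numbers low and within the scatter of each other, no step beyond the scatter is expected in this assay, a number 0.5 percentage points higher from compound 1 to compound 3 (within the scatter). Compound 3 is therefore estimated at 12%, expected between 2% and 26%.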

Compound 3, a percentage reported as inhibition, at one concentration (the size of the read-out at that concentration, not a potency): 6.2%
Compound 3: the middle estimate sits 5.8 percentage points above what was measured; the range from low to high includes it.
By their numbers in this assay, from the lowest: compounds 3, 2 and 1 (each within the scatter of the next).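

On an oxygen on an aromatic ring, (4-fluorophenyl)carbamoyl can stand in place of 3-(((thiophen-2-yl)carbonyl)amino)propyl with no step beyond the scatter in this assay (a number 5.3 percentage points lower from compound 1 to compound 3 (within the scatter)). The earlier step exchanged only the end of the three-carbon chain, whereas this one replaces the whole substituent, chain included, so the flat picture now extends to a different kind of group on this oxygen. Nothing available explains why these numbers stay together.

On these data alone, all three compounds remain within the scatter of the next, so it remains open whether any group on this oxygen can move the reading in this assay beyond the scatter. A carboxylic acid or a piperidine amine at the end of a longer chain on this oxygen would be a further test of that question.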